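Compound 3: a Smaller Ring on the Side Chain

The compounds below may be only part of what the source reports. "The series", "measured", "known", "first", "only" and "open" are said of these compounds alone.

Compound 1 `CCO/C(O)=C1\C(COCCN2CC(=O)N=C2N)=NC(C)=C(C(=O)OC)C1c1ccccc1Cl` gives 20 nM in a functional assay (aorta) with Rattus norvegicus as the target; a higher number here means a weaker inhibitor, a lower number a stronger inhibitor. Compound 2 `CCO/C(O)=C1\C(COCCn2cnc3ccccc32)=NC(C)=C(C(=O)OC)C1c1ccccc1Cl` gives 20 nM in this assay.

Compound 2 stands level with compound 1: the step of no change at the digits printed from compound 1 to compound 2 (within the scatter) lay within the scatter. Compound 3 `CCO/C(O)=C1\C(COCCN2C(=O)CNC2=O)=NC(C)=C(C(=O)OC)C1c1ccccc1Cl` differs from compound 2 by 2,5-dioxoimidazolidin-1-yl in place of 1H-benzimidazol-1-yl on a saturated chain carbon, two bonds along the chain from an oxygen on a saturated carbon. Among the measured compounds shown here, the one measured step that bears on this, no change at the digits printed from compound 1 to compound 2 (within the scatter), exchanged a five-membered non-aromatic ring for the benzimidazole without a shift beyond the scatter. Returning to a five-membered non-aromatic ring is therefore expected to give no step beyond the scatter, a 1.3-fold higher number from compound 2 to compound 3 (0.10 log units; within the scatter). Compound 3 is estimated at 25 nM in this assay, expected between 8 nM and 80 nM.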

Compound 3, half-maximal inhibitory concentration: 31.6 nM
The estimate for compound 3 lay 1.3-fold (0.10 log units) below the measured number; low and high end bracket the measured number.
By their numbers in this assay, from the lowest: compounds 1, 2 and 3 (each within the scatter of the next).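

Exchanging 1H-benzimidazol-1-yl for 2,5-dioxoimidazolidin-1-yl gives in this assay a 1.6-fold higher number from compound 2 to compound 3 (0.20 log units; within the scatter), and exchanging the ring group of compound 1 for the same group gives a 1.6-fold higher number from compound 1 to compound 3 (0.20 log units; within the scatter). Among the compounds shown here, this position has now carried three different ring groups, with no step among them beyond the scatter. Nothing measured here explains why these groups read alike.

The compounds shown leave open whether an amine or a carboxylic acid in place of these rings would stay level. They also leave open what a longer chain carrying the same rings would do.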